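The compounds below may be only part of what the source reports. "The series", "measured", "known", "first", "only" and "open" are said of these compounds alone.

Measured compounds in a functional assay on HEK293 cells for antagonist activity at transient receptor potential cation channel subfamily V member 1 (Homo sapiens), read by calcium flux; on this read-out lower numbers stand for stronger inhibition and higher numbers for weaker inhibition:
- compound 1 `FC(F)(F)c1ccc(Nc2ncnc3sc(Nc4c(Cl)cccc4Cl)nc23)cc1`: 12 nM
- compound 2 `O=S(=O)(c1ccc(Nc2ncnc3sc(Nc4c(Cl)cccc4Cl)nc23)cc1)N1CCCC1`: 1 nM
- compound 3 `CC(C)N1CCN(c2nc(Nc3ccc(C(F)(F)F)cc3)c3nc(Nc4c(Cl)cccc4Cl)sc3n2)CC1`: 184 nM

Compound 1 holds the second highest of the three numbers in this assay. Its nearest neighbour is reached by a 12-fold lower number from compound 1 to compound 2 (1.08 log units; beyond the scatter), its furthest by a 15-fold higher number from compound 1 to compound 3 (1.19 log units; beyond the scatter). Both measured steps lie beyond the scatter and run in opposite directions, so single changes to this core have so far moved the number strongly.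

Compound 4 `CN(c1ccc(C(F)(F)F)cc1)c1ncnc2sc(Nc3c(Cl)cccc3Cl)nc12` differs from compound 1 by methyl in place of hydrogen on a nitrogen on an aromatic ring. Neither measured step bears on this place: the step to compound 2 replaces a group on an aromatic carbon, and the step to compound 3 adds a ring on another aromatic carbon. No comparable change at this nitrogen has been measured in the series, so no direction can be read from the data. Given that both recorded steps were large, a step beyond the scatter in this assay is expected for compound 4 as well, and with no anchor the estimate is set cautiously toward a higher number with a wide range. Compound 4 is expected to give 60 nM, between 10 nM and 400 nM, which corresponds to an expected 5.0-fold higher number from compound 1 to compound 4 (0.70 log units; beyond the scatter).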

Compound 4, half-maximal inhibitory concentration: > 5000 nM
Compound 4 gave a limit, no number (the forecaster's own chance of this, stated with the estimate: 5%); middle value at least 83-fold (1.92 log units) from the limit.
By their numbers in this assay, from the lowest: compound 2; then compound 1; then compound 3. At a limit, above all of these: compound 4.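

In this assay compound 4 gives > 5000 nM, which is a limit of the assay and not a number. Methyl in place of hydrogen on this nitrogen, a change of 1 heavy atom, gives an at least 410-fold higher number from compound 1 to compound 4 (2.61 log units; beyond the scatter), whereas the larger groups placed on aromatic carbons gave a 12-fold lower number from compound 1 to compound 2 (1.08 log units; beyond the scatter) and a 15-fold higher number from compound 1 to compound 3 (1.19 log units; beyond the scatter), so among the places shown this nitrogen is the one where the smallest change has the largest effect on the number, and the first where a single change takes the read-out to the limit. The true size of this step stays unresolved, and the result fixes only its lower bound: the limit of > 5000 nM in this assay, at which 1 of the 4 values shown sits.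

Still open, on these data alone, is whether the loss is particular to methyl or extends to other groups on this nitrogen, such as ethyl or acetyl, and whether an oxygen in place of this nitrogen would behave in the same way. Also open, as far as these compounds go, is whether (pyrrolidin-1-yl)sulfonyl in place of trifluoromethyl, which gave the lowest number, would recover any of the inhibition when the methyl is present.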